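Adding a Methoxy Group on a Second Core

A few compounds are considered here, and "the series" means these few. Any claim that something is new, unique, unknown or untested is made for them only; others in the source may bear on it.

Compound 1, `COc1ccc(-c2cc3cc(C4C(C#N)=C(N)OC5=C4C(=O)CCC5)cc(C(C)C)c3oc2=O)cc1`: in a functional assay on the whole organism (strain Swiss albino) with Mus musculus as the target, in the forced swim test, with a stated time of 5 min, at a dose of 0.5 mg/kg by the intraperitoneal route (on this read-out higher numbers stand for more inhibition at the one dose given (going by the name of the read-out) and lower numbers for less inhibition), compound 1 gives 69.7%.
Compound 2, `COc1ccc(-c2cc3cc(C4C(C#N)=C(N)OC5=C4C(=O)CCC5)cc(C(C)C)c3oc2=O)cc1OC`: in this assay compound 2 gives 57.2%.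
Compound 3, `CCC(C)c1cc(C2C(C#N)=C(N)OC3=C2C(=O)CC(C)(C)C3)cc2cc(-c3ccc(OC)cc3)c(=O)oc12`: in this assay compound 3 gives 26.9%.

Between compound 1 and compound 2 the change is methoxy in place of hydrogen on an aromatic carbon. This change made the step of a number 12.5 percentage points lower from compound 1 to compound 2 (beyond the scatter). Compound 3 has the lowest number of the three; the difference between its core and the core of compound 1 is not broken down here.

Compound 4, `CCC(C)c1cc(C2C(C#N)=C(N)OC3=C2C(=O)CC(C)(C)C3)cc2cc(-c3ccc(OC)c(OC)c3)c(=O)oc12`, has not been measured. It differs from compound 3 by methoxy in place of hydrogen on an aromatic carbon, the same change as between compound 1 and compound 2. The expected step is a number 9.9 percentage points lower from compound 3 to compound 4 (within the scatter), resting on a number 12.5 percentage points lower from compound 1 to compound 2 (beyond the scatter); compound 3 starts lower in this assay, so a somewhat smaller drop is expected. Compound 4 is estimated at 17%, between 5% and 30%.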

Compound 4, a percentage reported as inhibition, in the whole organism at one dose (the size of the read-out at that dose, not a potency): 57.4%
Compound 4: middle estimate off by 40.4 percentage points, on the low side; the measured number lies above the stated range.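

On the second core, the change from 4-methoxyphenyl to 3,4-dimethoxyphenyl gave a number 30.5 percentage points higher from compound 3 to compound 4 (beyond the scatter) in this assay. The same change thus moved the number in opposite directions on the two cores, so in this series a step read on one core did not carry over to the other: the same change on two cores in this assay, a number 12.5 percentage points lower (beyond the scatter) from compound 1 to compound 2 and a number 30.5 percentage points higher (beyond the scatter) from compound 3 to compound 4, 43 percentage points apart, beyond the scatter of two such steps This does not show why the direction reverses, and two pairs give no rule for any further core.

The compounds shown leave open which part of the difference between the two cores goes with the reversal. They also leave open how a hydroxyl or an ethoxy group in place of the added methoxy would behave on either core.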